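Changing the Amine End of a Side Chain

This account rests on a few compounds, and the source may have more. Where it says the series, first, only, none or still open, it means among the compounds named here.

In a functional assay on MCF7 cells (Homo sapiens) for antiproliferative activity (on this read-out lower numbers stand for stronger inhibition and higher numbers for weaker inhibition), compound 1 `CC(C)=CCc1cc(C(=O)Nc2cc3ccc(OCC4CCCNC4)c(C)c3oc2=O)ccc1O` gives 790 nM, and compound 2 `CC(C)=CCc1cc(C(=O)Nc2cc3ccc(OCCCN(C(C)C)C(C)C)c(C)c3oc2=O)ccc1O` gives 1310 nM. Among the compounds with values here, these are the only two numbers measured so far, and compound 2 stands within the scatter of compound 1, so neither can be ranked over the other. Compound 3 `CC(C)=CCc1cc(C(=O)Nc2cc3ccc(OCCCNCC(N)=O)c(C)c3oc2=O)ccc1O` keeps the shared core and differs from compound 2 as follows: (carbamoylmethyl)amino in place of diisopropylamino on a saturated chain carbon, three bonds along the chain from an oxygen on an aromatic ring. In words, (carbamoylmethyl)amino sits in place of diisopropylamino on a saturated chain carbon, three bonds along the chain from an oxygen on an aromatic ring. Within the data shown here, the one measured step that bears on this, a 1.7-fold higher number from compound 1 to compound 2 (0.22 log units; within the scatter), also falls at the amine end of the side chain, and on that evidence no shift beyond the scatter is expected in this assay. Among the measured compounds shown here, no measured compound carries the entering group, so the data give no direction for it. The estimated move is small: a 1.1-fold lower number from compound 2 to compound 3 (0.04 log units; within the scatter). For compound 3 the expected value is 1200 nM, with an estimated range from 500 nM to 3500 nM.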

Compound 3, half-maximal inhibitory concentration: 1460 nM
Compound 3: middle estimate off by 1.2-fold (0.09 log units), on the low side; measured number inside the range.
By their numbers in this assay, from the lowest: compounds 1, 2 and 3 (each within the scatter of the next).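

In this assay, the step of a 1.1-fold higher number from compound 2 to compound 3 (0.05 log units; within the scatter) comes with an exchange of diisopropylamino, which has 7 heavy atoms and 0 hydrogen-bond donors, for (carbamoylmethyl)amino, which has 5 heavy atoms and 2 hydrogen-bond donors. The earlier pair had shown only a change from piperidin-3-yl to 2-(diisopropylamino)ethyl, whereas the comparison with the first compound now gives a 1.8-fold higher number from compound 1 to compound 3 (0.27 log units; within the scatter) for 2-((carbamoylmethyl)amino)ethyl in place of piperidin-3-yl, so all three compounds lie within the scatter of one another and none can be ranked over another. Nothing available here explains why the numbers stay so close across these different amine ends.

The three compounds leave open whether this held-level result would extend to other ends on the same chain, such as a carboxylic acid in place of the carbamoyl group, a morpholine ring or a simple primary amine. They also leave open whether a longer chain or a shorter chain between the oxygen on the aromatic ring and the amine would stay within the scatter in this read-out.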